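Moving the Piperidine Attachment Point and Microsomal Stability

A few compounds are considered here, and "the series" means these few. Any claim that something is new, unique, unknown or untested is made for them only; others in the source may bear on it.

Compound 1 `c1ccc2c(c1)CN[C@@H](CN(CCC1CCNCC1)[C@H]1CCCc3cccnc31)C2` was tested in an ADME assay on microsomes from liver (Homo sapiens) for metabolic stability, read by LC-MS, with a stated time of 10 min, tested at 0.5 uM (a lower number here means that less of the compound is left, a higher number that more of the compound is left), where compound 1 gives 66%. Going by the values given here, compound 2 `c1cnc2c(c1)CN[C@H](CN(CCCN1CCNCC1)[C@H]1CCCc3cccnc31)C2` is the only other compound measured so far; in this assay compound 2 gives 100%. Compound 1 thus stands lowest of the two numbers, with compound 2 sitting higher by a margin beyond the usual scatter. Compound 2 differs from compound 1 in more than one place, so the two values are simply set side by side, without a counted step between them.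

Compound 3 `c1ccc2c(c1)CN[C@@H](CN(CC[C@H]1CCCNC1)[C@H]1CCCc3cccnc31)C2` has not yet been measured. It differs from compound 1 by piperidin-3-yl in place of piperidin-4-yl on a saturated chain carbon, two bonds along the chain from an amine nitrogen. The change is confined to piperidin-3-yl in place of piperidin-4-yl on a saturated chain carbon, two bonds along the chain from an amine nitrogen. Among the compounds with values here, no measured pair shows this change, so nothing in the data says how large a step to expect. The step from compound 1 to compound 3 is expected to be a number 2 percentage points lower from compound 1 to compound 3 (within the scatter), most likely no change beyond the scatter. Compound 3 is estimated to give 64% in this assay, within a range from 45% to 85%.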

Compound 3, percent of the compound remaining: 93%
Estimate against measurement, compound 3: 29 percentage points below; the whole stated range lies below it.
By their numbers in this assay, from the lowest: compound 1; then compounds 3 and 2 (each within the scatter of the next).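

Going by these compounds alone, the pair of compound 1 and compound 3 gives the first step in which a single place changes: in this assay, piperidin-3-yl in place of piperidin-4-yl on a saturated chain carbon, two bonds along the chain from an amine nitrogen, gives a reading of a number 27 percentage points higher from compound 1 to compound 3 (beyond the scatter). The two compounds hold the same atoms, joined differently, so in this pair the reading follows the point of attachment of the ring alone, which the two earlier compounds, differing in more than one place, could not show. Nothing available explains why this change moves the number as it does.

The compounds shown leave open whether the opposite configuration at the defined stereocentre of piperidin-3-yl would read the same, and whether this step would carry over to a different core. They also leave open how pyrrolidin-3-yl or a longer chain in the same place would read in this assay.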